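The compounds below may be only part of what the source reports. "The series", "measured", "known", "first", "only" and "open" are said of these compounds alone.

Compound 1 `COc1cc(OCc2ccccc2OC)c2cc(-c3cn4nc(OC)sc4n3)oc2c1`: 82%
Compound 2 `COc1cc(OCc2cccc(COc3ccccc3)c2)c2cc(-c3cn4nc(OC)sc4n3)oc2c1`: 86%
Compound 3 `COc1cc(OCc2cccc(Sc3ccccc3)c2)c2cc(-c3cn4nc(OC)sc4n3)oc2c1`: 80%

Three compounds built on one shared core have been run in an ADME assay on microsomes from liver (Homo sapiens) for metabolic stability, with a stated time of 10 min; a lower number here means that less of the compound is left, a higher number that more of the compound is left. Compound 1 gives 82%, compound 2 gives 86% and compound 3 gives 80%. Compound 3 holds the lowest of the three numbers, yet its nearest neighbour, compound 1, sits only slightly higher and within the scatter, and the gap to compound 2, the furthest of the three, is likewise within the scatter. All three values therefore belong to one band, and no order among them can be read.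

Compound 4 `COc1cc(OCc2cccc(C#N)c2)c2cc(-c3cn4nc(OC)sc4n3)oc2c1` has not been measured in this assay. It differs from compound 3 in one place: cyano in place of phenylsulfanyl on an aromatic carbon. Going by the values given here, only one measured step touches the same aromatic carbon, that from compound 2 to compound 3, and it was a number 6 percentage points lower from compound 2 to compound 3 (within the scatter), within the scatter. That step exchanged one large group for another, whereas here a large group gives way to a small one, so the measured data bear on the new step only loosely. With nothing pointing either way, no movement beyond the scatter is expected in this assay. Compound 4 is therefore estimated at 82%, with a range from 68% to 94%, which amounts to an expected step of a number 2 percentage points higher from compound 3 to compound 4 (within the scatter).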

Compound 4, percent of the compound remaining: 100%
Compound 4: the middle estimate sits 18 percentage points below what was measured; measured number outside the range, above it.
By their numbers in this assay, from the lowest: compounds 3, 1 and 2 (each within the scatter of the next); then compound 4.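

In this assay, this aromatic carbon proves able to shift the read-out beyond the scatter: cyano gives a clear rise over phenylsulfanyl (a number 20 percentage points higher from compound 3 to compound 4 (beyond the scatter)) and over phenoxymethyl (a number 14 percentage points higher from compound 2 to compound 4 (beyond the scatter)), whereas exchanging those two ring-bearing groups for each other moved the number only within the scatter (a number 6 percentage points lower from compound 2 to compound 3 (within the scatter)). Compound 4 also stands apart from compound 1, where 3-cyanophenyl replaces 2-methoxyphenyl on a saturated chain carbon bound to an oxygen on an aromatic ring (a number 18 percentage points higher from compound 1 to compound 4 (beyond the scatter)), so it alone leaves the band that holds the other three compounds. No measurement shown here offers an explanation for this rise.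

The compounds shown do not separate the effect of the nitrile itself from that of losing the second aromatic ring, as both changes arrive together in each step to compound 4. Going by these compounds, how a methyl group, a chlorine atom, a primary amide or a carboxylic acid on the same aromatic carbon would read in this assay remains open, and so does whether any of them would join compound 4 or stay with the other three.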